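The source may report more compounds than this note shows. Statements on the series, on what has been measured and on what is new or still open speak of the compounds shown alone.

Measured in an ADME assay on BJ cells (Homo sapiens) for cytotoxicity, read by luminescence, with a stated time of 72 h (a higher number here means that more compound is needed for the effect, a lower number that less compound is needed), where every value is a limit of the assay:

Compound 1 `CCOC(=O)c1c(-c2cccc(C)c2)[nH]c2cc(OC)ccc2c1=O`: > 21500 nM
Compound 2 `CCOC(=O)c1c(-c2cccc(OC(C)C)c2)[nH]c2cc(OC)ccc2c1=O`: > 21500 nM
Compound 3 `CCCCOc1cccc(-c2[nH]c3cc(OC)ccc3c(=O)c2C(=O)OCC)c1`: > 21500 nM

Compound 3 gives > 21500 nM, which is a limit and not a number. The other two compounds stand at the same point, as the limit of > 21500 nM in this assay, at which 3 of the 3 values shown sit, shows.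

The next compound is compound 4 `CCOC(=O)c1c(-c2cccc(C(F)(F)F)c2)[nH]c2cc(OC)ccc2c1=O`, which has trifluoromethyl in place of butoxy on an aromatic carbon. This carbon belongs to a six-membered aromatic ring of carbon only, meta to a large group.

Within the data shown here, three measured steps bear on this change, since each alters the same substituent: a step that the two limits leave unreadable from compound 1 to compound 2, a step that the two limits leave unreadable from compound 1 to compound 3 and a step that the two limits leave unreadable from compound 2 to compound 3. None has a readable size, so they show no direction. Methyl, isopropoxy and butoxy all leave the compounds at one limit in this assay, so no step beyond the scatter is expected. The expected step is a step that the limit leaves unreadable from compound 3 to compound 4.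

Compound 4 is expected at 25000 nM, with an estimated range of 14000 nM to 45000 nM.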

Compound 4, half-maximal effective concentration: > 21500 nM
Compound 4 was reported as a limit (the forecaster's own chance of this, stated with the estimate: 85%); the middle value is on the limit's open side.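

Compound 4 gives > 21500 nM, which is a limit and not a number. No step from compound 1, compound 2 or compound 3 to compound 4 can be read, because all four compounds sit at one limit: the limit of > 21500 nM in this assay, at which 4 of the 4 values shown sit.

The compounds shown leave open how much of each is needed for the effect in this assay, and whether swapping the group on the aromatic carbon changes that amount at all.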